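The source may hold more compounds than are shown below. What is called first, only, known or untested is meant among the compounds shown, and "the series" means these compounds.

Measured so far:
- compound 1, `CCN1CCc2c(sc(NC(=O)Nc3ccc4ccccc4c3)c2C(N)=O)C1`: 1780 nM
- compound 2, `CC(C)(C)CN1CCc2c(sc(NC(=O)Nc3ccc(Cl)cc3)c2C(N)=O)C1`: 5560 nM

Compound 1, `CCN1CCc2c(sc(NC(=O)Nc3ccc4ccccc4c3)c2C(N)=O)C1`, has the lower of the two numbers in a functional assay (strain AB) with Danio rerio as the target, read by microscopy, with a stated time of 1 h; on this read-out lower numbers stand for an effect already at smaller amounts and higher numbers for an effect only at larger amounts of compound; compound 1 gives 1780 nM there. Compound 2, `CC(C)(C)CN1CCc2c(sc(NC(=O)Nc3ccc(Cl)cc3)c2C(N)=O)C1`, stands at the highest number of the two in this assay, where compound 2 gives 5560 nM; the gap between compound 2 and compound 1 lies beyond the scatter of this assay, and since the two compounds differ in more than one place, the gap is not broken down into steps here.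

Compound 3, `CC(C)(C)OC(=O)CCCCCN1CCc2c(sc(NC(=O)Nc3ccc(Cl)cc3)c2C(N)=O)C1`, is not yet measured. It differs from compound 2 in one place: 4-(tert-butoxycarbonyl)butyl in place of tert-butyl on a saturated chain carbon bound to an amine nitrogen in a ring. Among the measured compounds shown here, no measured pair shows what a change at this position does to the read-out, so the direction cannot be taken from the data. The expectation for the step is one of no change beyond the scatter, and the step from compound 2 to compound 3 is estimated as a 1.2-fold lower number from compound 2 to compound 3 (0.09 log units; within the scatter). Compound 3 is expected to give about 4500 nM in this assay, within a range from 1500 nM to 14000 nM, and the measurement will tell.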

Compound 3, half-maximal effective concentration: 620 nM
Compound 3: middle estimate off by 7.3-fold (0.86 log units), on the high side; measured number below the stated range.
By their numbers in this assay, from the lowest: compound 3; then compound 1; then compound 2.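

In this assay, among the compounds shown here, the group on a saturated chain carbon bound to an amine nitrogen in a ring proves able to move the read-out: 4-(tert-butoxycarbonyl)butyl in place of tert-butyl gives a 9.0-fold lower number from compound 2 to compound 3 (0.95 log units; beyond the scatter), the first single-place step and one beyond the scatter. The position therefore accepts a much larger group, with 11 heavy atoms entering where 4 leave, and the number falls rather than rises. Nothing measured on these compounds bears on why this step occurs.

The single step changes chain length and brings in the ester together, so the compounds shown cannot separate the two: a plain longer chain without the carbonyl, a carboxylic acid in place of the tert-butyl ester, or an amine at the chain end would each help to tell them apart. Also open, from the compounds shown here alone, is whether the step carries over to the other urea substituent of compound 1, which differs from compound 2 in more than one place.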